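This account rests on a few compounds, and the source may have more. Where it says the series, first, only, none or still open, it means among the compounds named here.

Measured compounds:
- compound 1, `Cc1nc(C#Cc2cc(F)cc(C#N)c2)cs1`: 0.08 nM
- compound 2, `N#Cc1cccc(C#Cc2csc(N)n2)c1`: 0.9 nM
- compound 3, `N#Cc1cc(F)cc(C#Cc2csc(N)n2)c1`: 0.25 nM

Of the compounds shown here, three sharing one core have been measured in an assay on brain for displacement of a labelled ligand from metabotropic glutamate receptor 5 (Rattus norvegicus); on this read-out higher numbers stand for weaker inhibition and lower numbers for stronger inhibition. Compound 3 sits second highest among these numbers: compound 1 lies closest, with the lower number of the three, while compound 2 gives the highest. The step from compound 2 to compound 3, a 3.6-fold lower number from compound 2 to compound 3 (0.56 log units; beyond the scatter), comes from a fluoro in place of hydrogen on the benzene-type ring and lies off to the side of the question here. The step that matters is a 3.1-fold higher number from compound 1 to compound 3 (0.49 log units; beyond the scatter), since it changes the same position that compound 4 alters: an amino in place of methyl on the five-membered ring, and the amino brought a higher number.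

Compound 4, `N#Cc1cc(F)cc(C#Cc2csc(Br)n2)c1`, differs from compound 3 in one place: bromo in place of amino on an aromatic carbon. Removing the amino, which in compound 1 came with a 3.1-fold higher number from compound 1 to compound 3 (0.49 log units; beyond the scatter) in the other direction, leads to the expectation of a modest step toward a lower number, roughly a 2.5-fold lower number from compound 3 to compound 4 (0.40 log units; beyond the scatter). Compound 4 is therefore estimated at 0.1 nM, within a range from 0.035 nM to 0.35 nM.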

Compound 4, inhibition constant: 0.95 nM
Compound 4: the middle estimate sits 9.5-fold (0.98 log units) below what was measured; measured number outside the range, above it.
By their numbers in this assay, from the lowest: compound 1; then compound 3; then compounds 2 and 4 (each within the scatter of the next).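

At this position the amino is not what pushes the number up: bromo in its place moves the number further up, not down (a 3.8-fold higher number from compound 3 to compound 4 (0.58 log units; beyond the scatter)). Methyl thus gives a lower number than either other group here, and the gap to bromo is large (a 12-fold higher number from compound 1 to compound 4 (1.07 log units; beyond the scatter)), so the choice of group on this one carbon can shift the number a long way in this assay. Nothing available explains this order of methyl, then amino, then bromo.

The compounds shown leave open where chloro, a methoxy group or a longer chain such as ethyl would fall in this order. They also leave open whether bromo would give a similar step on the core of compound 2, which carries hydrogen in place of the fluoro.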